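The compounds below may be only part of what the source reports. "The series", "measured", "known", "first", "only" and "open" are said of these compounds alone.

Measured compounds: compound 1 `CCOC(=O)CCO/N=C(/c1ccc(OC)c(OC)c1OC)c1cccc2ccccc12`, 10000 nM; compound 2 `COc1ccc(C(O)(Cc2ccc(F)cc2)c2cccc3ccccc23)c(OC)c1OC`, > 20000 nM.

Within the data shown here, in a functional assay on HCT-116 cells (Homo sapiens) for inhibition, read by sulforhodamine B assay, with a stated time of 48 h (on this read-out higher numbers stand for weaker inhibition and lower numbers for stronger inhibition), compound 1 gives 10000 nM, the only plain number among the values shown. Compound 2 reaches only > 20000 nM, which is a limit of the assay rather than a number (the limit of > 20000 nM in this assay, at which 1 of the 2 values shown sits). Compound 3 `COc1ccc(/C(=N/OCC(=O)O)c2cccc3ccccc23)c(OC)c1OC` differs from compound 1 by carboxy in place of (ethoxycarbonyl)methyl on a saturated chain carbon bound to an oxygen on an unsaturated carbon. Among the measured compounds shown here, no measured pair shows this change, so its size is unknown; a modest step toward weaker inhibition, or none beyond the scatter, is expected a 1.5-fold higher number from compound 1 to compound 3 (0.18 log units; within the scatter). Compound 3 is therefore estimated at 15000 nM, with a likely range from 5000 nM to 40000 nM.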

Compound 3, half-maximal inhibitory concentration: 4980 nM
For compound 3 the middle estimate is 3.0-fold (0.48 log units) above the measured one, and the stated range ends above it.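

In this assay, carboxy in place of (ethoxycarbonyl)methyl on a saturated chain carbon bound to an oxygen on an unsaturated carbon gives a 2.0-fold lower number from compound 1 to compound 3 (0.30 log units; within the scatter). This position therefore accepts the carboxymethyl end as well as the 2-(ethoxycarbonyl)ethyl end, and the two compounds cannot be told apart on this read-out. Nothing measured here bears on this step. The compounds shown leave open how an amine or an amide at the end of this chain would read. They also leave open the effect of a longer chain ending in carboxy.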